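Series notes: methoxy for methyl on the aryl ring

This account rests on a few compounds, and the source may have more. Where it says the series, first, only, none or still open, it means among the compounds named here.

Measured so far:
compound 1 `CSc1ccc(C)cc1NCC1=NCCN1`, 0.11 nM
compound 2 `Cc1ccc(S(C)(=O)=O)c(NCC2=NCCN2)c1`, 1.95 nM
compound 3 `CSc1cc(F)ccc1NCC1=NCCN1`, 7.76 nM

In a functional assay for agonist activity at Alpha-1A adrenergic receptor (Homo sapiens) (a lower number here means that less compound is needed, a higher number that more compound is needed for the effect), compound 1 gives the lowest number of the three; compound 2 comes nearest, and compound 3 stands furthest away. The single step that links two of these compounds directly is an 18-fold higher number from compound 1 to compound 2 (1.25 log units; beyond the scatter), a large move in the direction of more compound needed. Compound 3 differs from compound 1 in more than one place, so its value is read on its own.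

Compound 4 `COc1ccc(SC)c(NCC2=NCCN2)c1` has not been measured. It is reached from compound 1 by methoxy in place of methyl on an aromatic carbon. For the measured compounds named here, no measured step changes a group at this place or exchanges a methyl for a methoxy, so the step from compound 1 to compound 2 and the value of compound 3 offer only indirect guidance: substituents on this ring can shift the number strongly, yet the present change is small in atom count and keeps the methylsulfanyl group that compound 1 carries.

The expectation is therefore a small shift, a 2.7-fold higher number from compound 1 to compound 4 (0.44 log units; beyond the scatter), which may not exceed the scatter. Compound 4 is estimated at 0.3 nM in this assay, with a range from 0.07 nM to 1.5 nM.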

Compound 4, half-maximal effective concentration: 1.59 nM
The estimate for compound 4 lay 5.3-fold (0.72 log units) below the measured number; measured number outside the range, above it.
By their numbers in this assay, from the lowest: compound 1; then compounds 4 and 2 (each within the scatter of the next); then compound 3.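

In this assay the aromatic carbon para to a methylsulfanyl group now has a step of its own, and that step is large: methoxy in place of methyl gives a move (with a 14-fold higher number from compound 1 to compound 4 (1.16 log units; beyond the scatter)) in the direction of more compound needed. The change is modest in what is counted, with methyl of 1 heavy atom leaving and methoxy of 2 heavy atoms, with 1 hydrogen-bond acceptor, entering, so a small exchange at this place is enough to produce a large move. Together with the earlier step (with an 18-fold higher number from compound 1 to compound 2 (1.25 log units; beyond the scatter)), both single changes read so far from compound 1, one at this place and one at the methylsulfanyl group, go the same way and are large, and no information at hand explains either of them.

Open, on these data alone, is whether the move follows the oxygen of methoxy or the longer group as such, which an ethyl, a hydroxyl or a chlorine at this place would begin to separate. Also open, as far as these compounds go, is whether a longer chain such as ethoxy, or an amine, at this place would move the number further in this assay or bring it back towards that of compound 1.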